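Halogen Shifted from 2-Bromophenyl to 3-Chlorophenyl

This account rests on a few compounds, and the source may have more. Where it says the series, first, only, none or still open, it means among the compounds named here.

Three compounds share one core and differ only in the phenyl group on the amino nitrogen. Compound 1 `C=CC(=O)Nc1cccc(NC(=O)CSc2nc(Nc3ccccc3)c3ccccc3n2)c1` carries plain phenyl, and in a functional assay on PC-3 cells (Homo sapiens) for inhibition, read by MTT assay, with a stated time of 72 h (a lower number here means a stronger inhibitor, a higher number a weaker inhibitor), compound 1 gives 8740 nM. Compound 2 `C=CC(=O)Nc1cccc(NC(=O)CSc2nc(Nc3ccccc3Cl)c3ccccc3n2)c1` carries a chlorine on that phenyl, and in this assay compound 2 gives 14400 nM. Compound 3 `C=CC(=O)Nc1cccc(NC(=O)CSc2nc(Nc3ccccc3Br)c3ccccc3n2)c1` carries a bromine, and in this assay compound 3 gives 17100 nM. Compound 3 stands at the top of the three numbers, yet every gap is within the scatter: a 2.0-fold higher number from compound 1 to compound 3 (0.29 log units; within the scatter), a 1.2-fold higher number from compound 2 to compound 3 (0.07 log units; within the scatter), and a 1.6-fold higher number from compound 1 to compound 2 (0.22 log units; within the scatter).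

Compound 4 `C=CC(=O)Nc1cccc(NC(=O)CSc2nc(Nc3cccc(Cl)c3)c3ccccc3n2)c1` is not yet measured. It differs from compound 3 by 3-chlorophenyl in place of 2-bromophenyl on a nitrogen on an aromatic ring. Going by the values given here, the steps that bear on this change are the three halogen steps just named, and none of them left the scatter. Hence no step beyond the scatter is expected, and a 1.4-fold lower number from compound 3 to compound 4 (0.15 log units; within the scatter) is the estimate. Compound 4 is expected in this assay at 12000 nM, with a range from 5000 nM to 30000 nM.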

Compound 4, half-maximal inhibitory concentration: 12300 nM
Beside the measured number, compound 4's estimate is 1.0-fold (0.01 log units) below it; low and high end bracket the measured number.
By their numbers in this assay, from the lowest: compounds 1, 4, 2 and 3 (each within the scatter of the next).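

In this assay, moving the halogen on the phenyl group produces no step beyond the scatter: 3-chlorophenyl in place of 2-chlorophenyl gives a 1.2-fold lower number from compound 2 to compound 4 (0.07 log units; within the scatter), and 3-chlorophenyl in place of 2-bromophenyl gives a 1.4-fold lower number from compound 3 to compound 4 (0.14 log units; within the scatter). Chloro in place of hydrogen in the new placement also stays within the scatter, at a 1.4-fold higher number from compound 1 to compound 4 (0.15 log units; within the scatter), so among these four compounds neither the identity of the halogen nor its placement on the phenyl separates the numbers. No supporting evidence is available to explain this flat result.

The compounds shown carry only hydrogen, chloro or bromo on this phenyl, so it remains open whether a methoxy group, a carboxylic acid or a dimethylamino group there would leave the scatter. From the compounds shown here alone, whether 3-bromophenyl would behave like 3-chlorophenyl also remains open.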